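The source may hold more compounds than are shown below. What is called first, only, known or untested is meant among the compounds shown, and "the series" means these compounds.

Working notes on the series. Compound 1 `Cc1nn(C)c(Oc2cccc(F)c2)c1/C=N\CCCCCOc1cc2oc(=O)cc(C)c2cc1Cl` is the reference; in a functional assay on U-87MG ATCC cells for antiproliferative activity against U-87 MG (Homo sapiens), read by MTT assay, with a stated time of 72 h (a higher number here means a weaker inhibitor, a lower number a stronger inhibitor), compound 1 gives 9870 nM. Compound 2 `Cc1nn(C)c(Oc2ccc(Br)cc2)c1/C=N\CCCCCOc1cc2oc(=O)cc(C)c2cc1Cl` carries a different halogenated aryl on the same oxygen, and in this assay compound 2 gives 15300 nM. Within the data shown here, the one measured step, a 1.6-fold higher number from compound 1 to compound 2 (0.19 log units; within the scatter), shows that swapping the halogen and its position on this aryl left the number where it was. Compound 3 `Cc1nn(C)c(Oc2ccccc2F)c1/C=N\CCCCCCOc1cc2oc(=O)cc(C)c2cc1Cl` extends the chain by one carbon and carries a 2-fluorophenyl. In this assay compound 3 gives only > 25000 nM, which is a limit of the assay and not a number. Compound 3 therefore stands at the weak end of the three values shown, at the limit of > 25000 nM in this assay, at which 1 of the 3 values shown sits, in this assay.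

Compound 4 `Cc1nn(C)c(Oc2ccc(F)c(F)c2)c1/C=N\CCCCCCOc1cc2oc(=O)cc(C)c2cc1Cl` differs from compound 3 in one place: 3,4-difluorophenyl in place of 2-fluorophenyl on an oxygen on an aromatic ring. Among the measured compounds shown here, the only measured step, the halogen swap on the aryl from compound 1 to compound 2, stayed within the scatter, and nothing measured separates the difluoro pattern from the monofluoro one. No step beyond the scatter is expected in this assay. The expected step is a step that the limit leaves unreadable from compound 3 to compound 4. Compound 4 is estimated at 30000 nM, in the range 10000 nM to 90000 nM, with a limit again likely.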

Compound 4, half-maximal inhibitory concentration: > 25000 nM
Compound 4 was reported as a limit; the forecaster's own chance of this, stated with the estimate: 65%; the middle value does not contradict the limit.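

In this assay compound 4 gives > 25000 nM, a limit of the assay and not a number. Compound 3 also stands at a limit, so no step can be read between compound 3 and compound 4. The compounds shown leave open whether 3,4-difluorophenyl in place of 2-fluorophenyl changes the number at all, with the reading resting on: the limit of > 25000 nM in this assay, at which 2 of the 4 values shown sit.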